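The source may hold more compounds than are shown below. What is called first, only, known or untested is meant among the compounds shown, and "the series" means these compounds.

Measured compounds:
- compound 1, `O=C(CN(c1nc(Cl)nc2[nH]cnc12)C1CC1)N[C@@H](CO)C(=O)OCc1ccccc1`: 31.9%
- compound 2, `NC(=O)CC[C@H](NC(=O)CN(c1ncnc2c1ncn2C1CCCCO1)C1CC1)C(=O)OCc1ccccc1`: 47%
- compound 3, `O=C(O)[C@@H]1CCCN1C(=O)CN(c1nc(Cl)nc2[nH]cnc12)C1CC1`: 31.5%

All three were tested in a functional assay on the whole organism (Tail, strain ICR) with Mus musculus as the target, in the tail flick test, with a stated time of 30 min, at a dose of 25 umol/kg by the oral route; on this read-out higher numbers stand for a stronger effect at the one dose given and lower numbers for a weaker effect. Among these three numbers compound 1 stands second highest. Its nearest neighbour is compound 3, whose value is within the scatter of compound 1, so the two cannot be told apart. Compound 2, which carries a different core and a different side chain, gives a value that lies beyond the scatter above compound 1, and it is the only one of the three that does.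

The next compound, compound 4, `N=C(N)NCCC[C@H](NC(=O)CN(c1nc(Cl)nc2[nH]cnc12)C1CC1)C(=O)OCc1ccccc1`, differs from compound 1 in one place: a group of 6 heavy atoms (3 carbon, 3 nitrogen; no ring) in place of one oxygen atom, on a saturated chain carbon, two bonds along the chain from an amide-type nitrogen and a carbonyl carbon. For the measured compounds named here, no pair of measured compounds shows the effect of this particular exchange, so there is no measured step to lean on. Going by the values given here, the only hint comes from compound 2, whose larger side chain goes with a value of 47%, higher than compound 1; on that thin basis a modest upward step is expected rather than none. The expected step is a number 8.1 percentage points higher from compound 1 to compound 4 (within the scatter). For compound 4 the estimate is 40%, with a range from 24% to 56%.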

Compound 4, a percentage reported as activity, at one dose (the size of the read-out at that dose, not a potency): 23.2%
Compound 4: middle estimate off by 16.8 percentage points, on the high side; measured number below the stated range.
By their numbers in this assay, from the lowest: compounds 4, 3 and 1 (each within the scatter of the next); then compound 2.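

Putting a group of 6 heavy atoms (3 carbon, 3 nitrogen; no ring) in place of the hydroxy gives a number 8.7 percentage points lower from compound 1 to compound 4 (within the scatter) in this assay. For the compounds shown here, this is the first exchange that can be read on its own. Going by these compounds alone, compound 1 and compound 4 differ in one place, whereas the earlier compounds differ from each other in more than one. It shows that, on the saturated chain carbon two bonds along the chain from an amide-type nitrogen and a carbonyl carbon, a much larger group with more hydrogen-bond donors can take the place of the hydroxy without a change that this test can separate from the usual scatter. Nothing in the data explains this outcome.

Within the data shown here, with only one exchange at this carbon, it remains open whether a plain amine, a methoxy group or a longer chain ending in neither would move the number beyond the scatter. As far as these compounds go, it is also open whether the same exchange would give a similar step on a different core or with a different ester.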